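Notes on the step from compound 3 to compound 4

The source may hold more compounds than are shown below. What is called first, only, known or untested is meant among the compounds shown, and "the series" means these compounds.

Measured so far in a physicochemical assay for solubility, in phosphate buffer, with a stated time of 18 h, at pH 7.4 (on this read-out lower numbers stand for lower solubility and higher numbers for higher solubility), as follows
- compound 1 `COc1cc2ncnc(-n3nc(-c4ccccn4)nc3N)c2cc1N` gives 3000 nM
- compound 2 `COc1cc2ncnc(-n3nc(-c4ccccn4)cc3N)c2cc1OC` gives 1000 nM
- compound 3 `COc1cc2ncnc(-n3nc(-c4ccccn4)nc3N)c2cc1OCCCCNC(=O)OC(C)(C)C` gives 500 nM

Compound 3 at 500 nM lies within the scatter of compound 2 at 1000 nM in these notes. The gap between compound 3 and compound 1 at 3000 nM lies beyond the scatter, and compound 3 has the lower number of the two.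

Compound 4 `COc1cc2ncnc(-n3nc(-c4ccccn4)nc3N)c2cc1OCCCNC(=O)OCC(C)(C)C` is not yet measured. Its difference from compound 3 is ((neopentyloxycarbonyl)amino in place of ((tert-butoxycarbonyl)amino)methyl on a saturated chain carbon, three bonds along the chain from an oxygen on an aromatic ring) on a saturated chain carbon, three bonds along the chain from an oxygen on an aromatic ring. The two have the same atoms, joined differently, and the change also reads as 4-((tert-butoxycarbonyl)amino)butyl to 3-((neopentyloxycarbonyl)amino)propyl.

Among the measured compounds shown here, no measured pair differs in one place only, so no measured step guides the expectation. The starting point is compound 3 at 500 nM with no shift beyond the scatter expected in this assay for this exchange. The expected step is no change at the digits printed from compound 3 to compound 4 (within the scatter) as an estimate. For compound 4 the estimated value is 500 nM with an expected range of 150 nM to 1500 nM in this read-out.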

Compound 4, solubility: 200 nM
Compound 4: the middle estimate sits 2.5-fold (0.40 log units) above what was measured; the measured number falls inside the stated range.
By their numbers in this assay, from the lowest: compound 4; then compounds 3 and 2 (each within the scatter of the next); then compound 1.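

In this assay the series now has its first step between compounds that differ in one place: (neopentyloxycarbonyl)amino in place of ((tert-butoxycarbonyl)amino)methyl gives a 2.5-fold lower number from compound 3 to compound 4 (0.40 log units; beyond the scatter) on a saturated chain carbon, three bonds along the chain from an oxygen on an aromatic ring. The two groups have the same atoms and the same counts, so at this position the number can move beyond the scatter with no change in composition, only in how the atoms are joined. The data offer no measurement that explains this step.

The exchange alters the chain and the group on the carbonyl together, so this single pair cannot separate 4-((tert-butoxycarbonyl)amino)butyl to 3-((neopentyloxycarbonyl)amino)propyl into two contributions. Going by these compounds, how a free amine or a carboxylic acid would read at this place also remains open.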